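Swapping One Hydrogen for Bromo in Compound 1

The source may report more compounds than this note shows. Statements on the series, on what has been measured and on what is new or still open speak of the compounds shown alone.

In a functional assay on HCT-116 cells (Homo sapiens) for antiproliferative activity, read by MTT assay, with a stated time of 72 h (a higher number here means a weaker inhibitor, a lower number a stronger inhibitor), compound 1 `COc1cc(CCc2ccccc2)cc(OC)c1O` gives 530 nM and serves as the reference point here. Two close relatives each carry a single fluoro in place of hydrogen on its unsubstituted aromatic ring, and they behave very differently. Compound 3 `COc1cc(CCc2ccccc2F)cc(OC)c1O` gives 880 nM and the step of a 1.7-fold higher number from compound 1 to compound 3 (0.22 log units; within the scatter) lies within the scatter, so compound 1 and compound 3 stand level. Compound 2 `COc1cc(CCc2cccc(F)c2)cc(OC)c1O` gives 7570 nM and the step of a 14-fold higher number from compound 1 to compound 2 (1.15 log units; beyond the scatter) is large and beyond the scatter, so compound 1 stands well clear of it.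

Compound 4 `COc1cc(CCc2ccc(Br)cc2)cc(OC)c1O` alters the same ring. The change bromo in place of hydrogen on an aromatic carbon puts bromo in place of hydrogen on an aromatic carbon, para to a large group. Among the compounds with values here, only the two fluoro steps bear on this, and only loosely, since no measured compound here carries bromo. They show that one swap of this kind can cost nothing while another costs a great deal, so a wide range is honest. A rise in the number seems more likely than a fall, since neither fluoro step went downward. The expected step of a 2.8-fold higher number from compound 1 to compound 4 (0.45 log units; beyond the scatter) is a moderate one toward weaker inhibition. For compound 4 the estimated value is 1500 nM with an expected range from 400 nM to 6000 nM in this assay.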

Compound 4, half-maximal inhibitory concentration: 15900 nM
Compound 4: the middle estimate sits 11-fold (1.03 log units) below what was measured; the whole stated range lies below it.
By their numbers in this assay, from the lowest: compounds 1 and 3 (each within the scatter of the next); then compound 2; then compound 4.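

In this assay, one bromo on an aromatic carbon para to a large group, a change of a single heavy atom, gives a 30-fold higher number from compound 1 to compound 4 (1.48 log units; beyond the scatter) and marks the largest step from compound 1 among the compounds shown. Together with the fluoro steps, a 14-fold higher number from compound 1 to compound 2 (1.15 log units; beyond the scatter) and a 1.7-fold higher number from compound 1 to compound 3 (0.22 log units; within the scatter), this result shows that a single swap on this ring can leave the number within the scatter or raise it sharply, and that the upward steps are not confined to one spot or one group, since compound 2 and compound 4 differ from compound 1 in both the group added and its place. Within the data shown here, no measurement here explains why bromo at this place raises the number so far.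

The compounds shown leave open whether the large step belongs to bromo itself or to this place on the ring, as fluoro or chloro para to a large group would be needed to separate the two. They also leave open how an amine or a carboxylic acid on this same aromatic carbon would behave, and whether bromo elsewhere on the ring would cost as much.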